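The source may hold more compounds than are shown below. What is called first, only, known or untested is meant among the compounds shown, and "the series" means these compounds.

Measured so far in an assay on isolated protein for inhibition of malate dehydrogenase, mitochondrial (Homo sapiens), with a stated time of 30 min; on this read-out higher numbers stand for weaker inhibition and lower numbers for stronger inhibition:
compound 1 `COC(=O)c1ccc(O)c(NC(=O)CCOc2ccc(C(C)(C)CC(C)(C)C)cc2)c1` gives 4600 nM
compound 2 `CC(C)(C)CC(C)(C)c1ccc(OCC(=O)N2CCN(Cc3ccc(C(F)(F)F)cc3)CC2)cc1` gives 5400 nM

Going by the values given here, compound 2 is one of only two compounds with a number in this assay, and its value and that of compound 1 lie within the usual scatter of each other, so neither is separated from the other. Among the compounds with values here, no step between measured compounds that differ in one place exists, and the two measured compounds differ throughout, so nothing about the effect of a single change can be read from them.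

Compound 3 `C#CCN1CCN(C(=O)COc2ccc(C(C)(C)CC(C)(C)C)cc2)CC1` is the next compound for this assay. It differs from compound 2 in one place: ethynyl in place of 4-(trifluoromethyl)phenyl on a saturated chain carbon bound to an amine nitrogen in a ring. Within the data shown here, no measured pair shows what such a change does, so the expectation rests on the size of the change alone. The expected step from compound 2 to compound 3 is a 2.6-fold higher number from compound 2 to compound 3 (0.41 log units; beyond the scatter), toward a higher number and beyond the scatter, with low confidence. Compound 3 is therefore expected at 14000 nM, within a range from 4000 nM to 50000 nM; a limit instead of a number is possible.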

Compound 3, half-maximal inhibitory concentration: > 40000 nM
Compound 3 was reported as a limit; the forecaster's own chance of this, stated with the estimate: 30%; at least 2.8-fold (0.45 log units) between middle value and limit.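

Going by these compounds alone, the first single-place comparison shows that this position is not indifferent to the change in this assay: ethynyl in place of 4-(trifluoromethyl)phenyl on a saturated chain carbon bound to an amine nitrogen in a ring gives an at least 7.4-fold higher number from compound 2 to compound 3 (0.86 log units; beyond the scatter). Compound 3 is a limit, > 40000 nM, in this assay. The step is therefore only a lower bound, and its full size stays unread: the limit of > 40000 nM in this assay, at which 1 of the 3 values shown sits.

The compounds shown do not tell whether the difference follows the aromatic ring or the trifluoromethyl group, as 4-(trifluoromethyl)benzyl and propargyl differ in both. A plain benzyl or a cyclohexylmethyl on the same amine nitrogen would separate these two readings.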